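Swapping the aryl group on a piperazine ring

The source may report more compounds than this note shows. Statements on the series, on what has been measured and on what is new or still open speak of the compounds shown alone.

Of the compounds shown here, two have been tested in a functional assay on the whole organism (strain Wister albino) for inhibition, with Rattus norvegicus as the target, read by paw edema, with stated times of 30 min and 3 h, at a dose of 10 mg/kg by the oral route; a higher number here means more inhibition at the dose given (going by the name of the read-out), a lower number less inhibition. Compound 1, `CCOC(=O)C1CCN(Cn2nc(Cc3ccc(SC)cc3)oc2=S)CC1`, gives 57.4% in this assay. Compound 2, `CC(C)Cc1ccc(C(C)c2nn(CN3CCN(c4ccc(Cl)cc4)CC3)c(=S)o2)cc1`, gives 76.6% in this assay and so stands higher of the two numbers, with compound 1 lying below it by a gap beyond the usual scatter. Within the data shown here, no pair of measured compounds differs in a single place, so no direct step size has been measured yet.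

Compound 3, `CCOc1ccccc1N1CCN(Cn2nc(C(C)c3ccc(CC(C)C)cc3)oc2=S)CC1`, has not been measured. It differs from compound 2 by one change: 2-ethoxyphenyl in place of 4-chlorophenyl on an amine nitrogen in a ring. Among the measured compounds shown here, with no comparable step available, the expected step of a number 6.6 percentage points lower from compound 2 to compound 3 (within the scatter) is a small one, likely within the scatter and at most slightly downward. Compound 3 is therefore expected to give about 70% in this assay, with a range from 55% to 85%.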

Compound 3, a percentage reported as inhibition, in the whole organism at one dose (the size of the read-out at that dose, not a potency): 44.6%
The estimate for compound 3 lay 25.4 percentage points above the measured number; the measured number lies below the stated range.
By their numbers in this assay, from the lowest: compound 3; then compound 1; then compound 2.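

Among these compounds, this is the first comparison in the set that changes only one place, and it shows that the group on this amine nitrogen strongly affects the read-out in this assay. Putting 2-ethoxyphenyl in place of 4-chlorophenyl gives a number 32 percentage points lower from compound 2 to compound 3 (beyond the scatter), so this position does not accept every phenyl-type group equally, even though both groups carry one six-membered aromatic ring of carbon only. No supporting data link this loss to any particular difference between the two groups.

The change replaces both the substituent and its place on the phenyl ring, so the compounds shown cannot tell these two parts apart. A 4-ethoxyphenyl group or a plain phenyl group at the same nitrogen would leave the question of which part matters open to test.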